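The compounds below may be only part of what the source reports. "The series", "measured", "known", "first", "only" and "open" are said of these compounds alone.

Working notes on the series.

The series rests on two cores. Compound 1 `O=C1/C(=C/c2cccc(Br)c2)Cc2ccccc21` and compound 2 `Cc1cccc(/C=C2\Cc3ccccc3C2=O)c1` share one; compound 3 `O=C1/C(=C/c2cccc(Br)c2)CCCc2ccccc21` and the as yet unmeasured compound 4 `Cc1cccc(/C=C2\CCCc3ccccc3C2=O)c1` share the other. How the two cores differ is not broken down here.

In a functional assay on MOLT-4 cells (Homo sapiens) for inhibition (on this read-out higher numbers stand for weaker inhibition and lower numbers for stronger inhibition), compound 1 gives 173000 nM, and compound 2 gives 80300 nM. The step between them, (methyl in place of bromo on an aromatic carbon), made a 2.2-fold lower number from compound 1 to compound 2 (0.33 log units; beyond the scatter). Among the compounds with values here, on the second core compound 3 gives 17100 nM in this assay, the lowest number measured so far.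

Compound 4 carries the same change relative to compound 3, (methyl in place of bromo on an aromatic carbon), with the place described in the same words as for the earlier pair. Only one measured occurrence of this change exists, so any expectation is loosely held. Compound 4 is expected to sit at 8000 nM in this assay, within 3500 nM to 20000 nM, which means a step of a 2.1-fold lower number from compound 3 to compound 4 (0.33 log units; beyond the scatter); this rests on the step seen from compound 1 to compound 2, a 2.2-fold lower number from compound 1 to compound 2 (0.33 log units; beyond the scatter), applied to compound 3, which gives 17100 nM.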

Compound 4, half-maximal inhibitory concentration: 34600 nM
Estimate against measurement, compound 4: 4.3-fold (0.64 log units) below; the whole stated range lies below it.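

On the core of compound 3, methyl in place of bromo on an aromatic carbon gives a 2.0-fold higher number from compound 3 to compound 4 (0.31 log units; beyond the scatter) in this assay, so the direction seen on the core of compound 1 does not carry over. Set side by side, the two steps differ in direction and lie apart by more than their scatter: the same change on two cores in this assay, a 2.2-fold lower number (0.33 log units; beyond the scatter) from compound 1 to compound 2 and a 2.0-fold higher number (0.31 log units; beyond the scatter) from compound 3 to compound 4, 4.4-fold (0.64 log units) apart, beyond the scatter of two such steps.
This shows that, for these two pairs, the outcome of this change cannot be read across from one core to the other; it does not show which feature of the cores lies behind the difference, and with one pair on each core it gives no rule for a further core.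

The compounds shown leave open whether other groups on the same aromatic carbon, such as chloro, methoxy or an amine, would follow bromo or methyl on either core. They also leave open whether the same reversal would appear in a different cell line.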